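The source may report more compounds than this note shows. Statements on the series, on what has been measured and on what is new or still open speak of the compounds shown alone.

Compound 2 `C=C(Br)C(=O)Nc1cccc(-c2cn3nc(CCc4ccccc4)sc3n2)c1` and compound 3 `C=C(Br)C(=O)Nc1cccc(-c2cn3nc(-c4ccc(Cl)cc4)sc3n2)c1` carry the same (1-bromoethenyl)carbonyl group on a nitrogen on an aromatic ring and differ only in their cores, (4-chlorophenyl in place of phenethyl on an aromatic carbon). In a functional assay on HeLa cells (Homo sapiens) for inhibition, read by cell counting, with a stated time of 4 days (on this read-out lower numbers stand for stronger inhibition and higher numbers for weaker inhibition), compound 2 gives 3300 nM and compound 3 gives 3000 nM, which is a 1.1-fold lower number from compound 2 to compound 3 (0.04 log units; within the scatter). Compound 1 `Nc1cccc(-c2cn3nc(CCc4ccccc4)sc3n2)c1` lacks that group, (hydrogen in place of (1-bromoethenyl)carbonyl on a nitrogen on an aromatic ring), and in this assay compound 1 gives 242000 nM, which is a 73-fold higher number from compound 2 to compound 1 (1.87 log units; beyond the scatter). Compound 4 `Nc1cccc(-c2cn3nc(-c4ccc(Cl)cc4)sc3n2)c1` has not been measured; it stands to compound 3 exactly as compound 1 stands to compound 2, the same change at the same place, (hydrogen in place of (1-bromoethenyl)carbonyl on a nitrogen on an aromatic ring). Because a 73-fold higher number from compound 2 to compound 1 (1.87 log units; beyond the scatter) was seen on a core whose exchange gave a 1.1-fold lower number from compound 2 to compound 3 (0.04 log units; within the scatter), a step of similar size is expected from compound 3 to compound 4. The expected step is a 67-fold higher number from compound 3 to compound 4 (1.82 log units; beyond the scatter). In this assay compound 4 is therefore estimated at 200000 nM, with a range from 50000 nM to 800000 nM.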

Compound 4, half-maximal inhibitory concentration: 160000 nM
Compound 4: middle estimate off by 1.3-fold (0.10 log units), on the high side; low and high end bracket the measured number.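

In this assay, hydrogen in place of (1-bromoethenyl)carbonyl on the second core gives a 53-fold higher number from compound 3 to compound 4 (1.73 log units; beyond the scatter), and the step matches the one seen on the first core: the same change on two cores in this assay, a 73-fold higher number (1.87 log units; beyond the scatter) from compound 2 to compound 1 and a 53-fold higher number (1.73 log units; beyond the scatter) from compound 3 to compound 4, 1.4-fold (0.14 log units) apart, within the scatter of two such steps

So the change carries over between these two cores, with the phenethyl and 4-chlorophenyl groups making no difference to its size beyond the scatter. Two cores do not show that it would carry over to every core in the series, and they do not explain why the step is so large.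

The compounds shown leave open how an acetyl or a plain propenoyl group on that nitrogen would compare with (1-bromoethenyl)carbonyl, and so whether the bromine matters. Also open, as far as these compounds go, is the size of the step on a core carrying an amine or a carboxylic acid in place of phenethyl or 4-chlorophenyl.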